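This account rests on a few compounds, and the source may have more. Where it says the series, first, only, none or still open, it means among the compounds named here.

Measured so far:
Compound 1 `Sc1nc(NCc2ccccc2)c2ccccc2n1` — in a functional assay on MCF7 cells (Homo sapiens) for cytotoxicity, read by MTT assay, with a stated time of 72 h (a lower number here means that less compound is tolerated, a higher number that more compound is tolerated), compound 1 gives > 100000 nM, a limit of the assay.
Compound 2 `COc1ccc(CNc2nc(S)nc3ccccc23)cc1` — compound 2 gives 78400 nM.
Compound 3 `CSc1ccc(CNc2nc(SC)nc3ccccc23)cc1` — compound 3 gives > 100000 nM, also a limit of the assay.

Compound 1 stands at a limit, not at a number, and so does compound 3; two of the three values sit at the limit of > 100000 nM in this assay, at which 2 of the 3 values shown sit. Among the measured compounds shown here, the one measured step, an at least 1.2-fold lower number from compound 1 to compound 2 (0.10 log units; that floor lies within the scatter), has a floor that lies within the scatter, so it shows no change that can be read as real.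

Compound 4 `C[Se]c1nc(NCc2ccccc2)c2ccccc2n1` differs from compound 1 in one place: a group of 2 heavy atoms (1 carbon, 1 selenium; no ring) in place of one sulfur atom, on an aromatic carbon. For the measured compounds named here, no measured step changes that place; the step from compound 1 to compound 2 concerns the methoxy group elsewhere and says nothing about the sulfur position. The step from compound 1 to compound 4 is therefore expected to stay within the scatter, a number no higher from compound 1 to compound 4 (the limit leaves the size open), with the result most likely again a limit rather than a number. Compound 4 is estimated at 100000 nM, in the range 40000 nM to 250000 nM.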

Compound 4, concentration lethal to 50% of the cells: > 100000 nM
Compound 4 was reported as a limit; the forecaster's own chance of this, stated with the estimate: 70%; the middle value lies on the limit itself.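

Compound 1 and compound 4 both stand at a limit in this assay, so no step can be read between them: the limit of > 100000 nM in this assay, at which 3 of the 4 values shown sit.

The compounds shown leave open whether replacing sulfanyl with the group of 2 heavy atoms (1 carbon, 1 selenium) on that aromatic carbon changes the read-out at all.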